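Swapping the acid-bearing chain on the oxime for a benzoic acid

A few compounds are considered here, and "the series" means these few. Any claim that something is new, unique, unknown or untested is made for them only; others in the source may bear on it.

Two compounds share a core and differ only in the group hanging from the oxime oxygen. Compound 1 `CC/C(=N\OC(c1ccc(OCc2ccc3ccccc3n2)cc1)C1CCCCC1)C(=O)O` gives 30 nM in a functional assay for inhibition of Polyunsaturated fatty acid 5-lipoxygenase (Homo sapiens) (a lower number here means a stronger inhibitor, a higher number a weaker inhibitor), and compound 2 `CC(/C=C/C(=O)O)=N\OC(c1ccc(OCc2ccc3ccccc3n2)cc1)C1CCCCC1` gives 40 nM in this assay. Compound 2 thus stands at the higher of the two numbers, though the step of a 1.3-fold higher number from compound 1 to compound 2 (0.12 log units; within the scatter) is within the scatter. Compound 3 `O=C(O)c1ccc(/C=N/OC(c2ccc(OCc3ccc4ccccc4n3)cc2)C2CCCCC2)cc1` carries the change (a group of 11 heavy atoms (8 carbon, 1 nitrogen, 2 oxygen; one six-membered aromatic ring of carbon only) in place of a group of 8 heavy atoms (5 carbon, 1 nitrogen, 2 oxygen; no ring), on an oxygen on a saturated carbon). Within the data shown here, the one step available, the chain lengthening from compound 1 to compound 2, barely moved the number, so a change at this same place is expected to bring a step of a 1.3-fold higher number from compound 2 to compound 3 (0.10 log units; within the scatter) at most, with no clear direction. Compound 3 is therefore estimated at 50 nM, within a range from 15 nM to 160 nM.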

Compound 3, half-maximal inhibitory concentration: 31 nM
Compound 3: middle estimate off by 1.6-fold (0.21 log units), on the high side, and the stated range covers the measured number.
By their numbers in this assay, from the lowest: compounds 1, 3 and 2 (each within the scatter of the next).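

In this assay, the group with a six-membered aromatic ring of carbon only gives a 1.3-fold lower number from compound 2 to compound 3 (0.11 log units; within the scatter) and a 1.0-fold higher number from compound 1 to compound 3 (0.01 log units; within the scatter) on the same oxygen. This position on the shared core therefore accepts a ring-bearing group as well as the two ring-free chains, with all three compounds within the scatter of one another. No measurement shown explains why these three read alike. Still open, from the compounds shown here alone, is how this position would respond if an amine or an amide replaced the carboxylic acid.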